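Extending the amine arm of compound 3 and the expected half-life

A few compounds are considered here, and "the series" means these few. Any claim that something is new, unique, unknown or untested is made for them only; others in the source may bear on it.

Measured so far:
- Compound 1 `Cc1csc2cc([C@H](C)Nc3ncnc(N)c3C#N)c(-c3cccc(CN4CCC(CN(C)Cc5ccccn5)CC4)c3)c(=O)n12` gives 10.9 h
- Compound 2 `Cc1csc2cc([C@H](C)Nc3ncnc(N)c3C#N)c(-c3cccc(CN4CCC(N(C)CC(C)C)CC4)c3)c(=O)n12` gives 9.9 h
- Compound 3 `Cc1csc2cc([C@H](C)Nc3ncnc(N)c3C#N)c(-c3cccc(CN4CCC(N(C)C)CC4)c3)c(=O)n12` gives 23.2 h

These three compounds share one core and differ only in the amine carried on the saturated ring. They were tested in an ADME assay on the whole organism (lung, Rattus norvegicus) for metabolic stability, read by LC-MS; a higher number here means that the compound lasts longer, a lower number that the compound disappears faster. Compound 3, which carries the smallest amine, stands highest of the three numbers: compound 1 sits at a 2.1-fold higher number from compound 1 to compound 3 (0.33 log units; beyond the scatter), and compound 2 at a 2.3-fold higher number from compound 2 to compound 3 (0.37 log units; beyond the scatter). The step between compound 1 and compound 2 is a 1.1-fold lower number from compound 1 to compound 2 (0.04 log units; within the scatter).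

The new compound 4 `Cc1csc2cc([C@H](C)Nc3ncnc(N)c3C#N)c(-c3cccc(CN4CCC(CN(C)CC(C)C)CC4)c3)c(=O)n12` takes compound 3 as its starting point and makes one change: (isobutyl(methyl)amino)methyl in place of dimethylamino on a saturated ring carbon. Compound 4 thus carries both features that compound 1 and compound 2 each add separately, the extra linking carbon and the branched chain.

For the measured compounds named here, two measured steps bear directly on this change, since both run from a larger amine to the dimethylamino of compound 3 and both raise the number modestly. Reversing that direction, a modest drop is expected, a 2.2-fold lower number from compound 3 to compound 4 (0.34 log units; beyond the scatter). Compound 4 is therefore estimated at 10.5 h, with a range from 6 h to 18 h.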

Compound 4, half-life in the lung assay: 12 h
Estimate against measurement, compound 4: 1.1-fold (0.06 log units) below, within the range that was stated.
By their numbers in the lung assay, from the lowest: compounds 2, 1, 4 and 3 (each within the scatter of the next, the first and the last beyond it).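

In the lung assay, the arm that combines the extra linking carbon with the branched chain reads no differently from the two earlier large amines: a 1.2-fold higher number from compound 2 to compound 4 (0.08 log units; within the scatter), and a 1.1-fold higher number from compound 1 to compound 4 (0.04 log units; within the scatter). Replacing dimethylamino with (isobutyl(methyl)amino)methyl on this saturated ring carbon gives a 1.9-fold lower number from compound 3 to compound 4 (0.29 log units; within the scatter), so this full enlargement of the amine does not produce a step beyond the scatter, unlike the steps that link compound 3 to compound 1 and compound 2. In a physicochemical assay for lipophilicity (on this read-out lower numbers stand for lower lipophilicity and higher numbers for higher lipophilicity), compound 3 gives 0.5 and compound 4 gives 2.1, which is a number 1.60 log units higher from compound 3 to compound 4 (beyond the scatter), so the same change that stays within the scatter for half-life produces a large step in distribution coefficient.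

Only compound 3 and compound 4 have both read-outs here, and one pair cannot show whether half-life follows the distribution coefficient across this series. Also open, on these data alone, is how half-life and distribution coefficient would respond to a hydroxyl group or a carboxylic acid on the isobutyl chain of this arm.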